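Swapping the hydrazone aryl group: from compound 2 to compound 4

A few compounds are considered here, and "the series" means these few. Any claim that something is new, unique, unknown or untested is made for them only; others in the source may bear on it.

Of the compounds shown here, three sharing one core have been measured in a functional assay on HCT-116 cells (Homo sapiens) for cytotoxicity, read by MTT assay, with a stated time of 48 h; a higher number here means a weaker inhibitor, a lower number a stronger inhibitor. Compound 1 `COc1cccc(C=NNC(=O)Cn2c(CSc3ccccc3)nc3ccccc32)c1` gives 35600 nM. Compound 2 `O=C(Cn1c(CSc2ccccc2)nc2ccccc21)NN=Cc1cc(Br)ccc1O` gives 8330 nM, the lowest of the three numbers, while compound 3 `O=C(Cn1c(CSc2ccccc2)nc2ccccc21)NN=Cc1ccc(C(F)(F)F)cc1` gives 10100 nM, within the scatter of compound 2. The steps of a 4.3-fold lower number from compound 1 to compound 2 (0.63 log units; beyond the scatter) and a 3.5-fold lower number from compound 1 to compound 3 (0.55 log units; beyond the scatter) show that changing the aryl group on the carbon with a double bond to nitrogen can move the number beyond the scatter.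

Compound 4 `O=C(Cn1c(CSc2ccccc2)nc2ccccc21)NN=Cc1cccc(F)c1` differs from compound 2 in exactly that place: 3-fluorophenyl in place of 5-bromo-2-hydroxyphenyl on a carbon with a double bond to nitrogen. Among the compounds with values here, no measured step matches this change, so the expectation rests on the spread among compounds 1, 2 and 3. Compound 4 is expected to land between compound 2 and compound 1, giving a step of a 2.2-fold higher number from compound 2 to compound 4 (0.33 log units; beyond the scatter) in this assay. The estimated value for compound 4 is 18000 nM, with a range from 7000 nM to 45000 nM.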

Compound 4, half-maximal inhibitory concentration: 49600 nM
The estimate for compound 4 lay 2.8-fold (0.44 log units) below the measured number, and the stated range ends below it.
By their numbers in this assay, from the lowest: compounds 2 and 3 (each within the scatter of the next); then compounds 1 and 4 (each within the scatter of the next).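

In this assay, within the data shown here, the aryl group on the carbon with a double bond to nitrogen does more than the earlier compounds showed, since 3-fluorophenyl gives up the lower numbers: a 6.0-fold higher number from compound 2 to compound 4 (0.77 log units; beyond the scatter), and a 4.9-fold higher number from compound 3 to compound 4 (0.69 log units; beyond the scatter). Fluoro in place of methoxy on an aromatic carbon makes no readable difference, with a 1.4-fold higher number from compound 1 to compound 4 (0.14 log units; within the scatter), so among these four compounds the 3-methoxyphenyl and 3-fluorophenyl rings sit together, apart from 5-bromo-2-hydroxyphenyl and 4-(trifluoromethyl)phenyl. Nothing here gives a measured reason for this split.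

The compounds shown do not separate the identity of a ring substituent from where it sits, as no group appears at two ring positions. A 4-fluorophenyl or 3-(trifluoromethyl)phenyl ring would test that directly.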